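Aryl swap at the imidazopyrazine: compound 3 planned

This account rests on a few compounds, and the source may have more. Where it says the series, first, only, none or still open, it means among the compounds named here.

Measured so far:
compound 1, `Fc1ccc(-c2cn3ccnc3c(-c3ccc4ncn(C5CCCCC5)c4c3)n2)cc1` — 7.59%
compound 2, `Fc1ccccc1-c1cn2ccnc2c(-c2ccc3ncn(C4CCCCC4)c3c2)n1` — 6.18%

In a functional assay on HCT-15 cells (Homo sapiens) for inhibition, read by sulforhodamine B assay, with a stated time of 48 h, tested at 10 uM (a lower number here means less inhibition, a higher number more inhibition at the concentration tested (going by the name of the read-out)), compound 2 gives 6.18%, and compound 1 gives 7.59%; both numbers are small and sit within the scatter of each other. Compound 3, `c1csc(-c2cn3ccnc3c(-c3ccc4ncn(C5CCCCC5)c4c3)n2)c1`, differs from compound 2 by thiophen-2-yl in place of 2-fluorophenyl on an aromatic carbon. For the measured compounds named here, the only measured step, a number 1.4 percentage points lower from compound 1 to compound 2 (within the scatter), moves a fluorine within the same ring and is the nearest point of reference; it showed no step beyond the scatter. The exchange of the aromatic ring itself has no measured counterpart, so nothing shown argues for a large step in either direction. For compound 3 the expected value in this assay is 7%, range 0% to 22%, which means an estimated step of a number 0.8 percentage points higher from compound 2 to compound 3 (within the scatter).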

Compound 3, a percentage reported as inhibition, at one concentration (the size of the read-out at that concentration, not a potency): 2.33%
Beside the measured number, compound 3's estimate is 4.7 percentage points above it; the range from low to high includes it.
By their numbers in this assay, from the lowest: compounds 3, 2 and 1 (each within the scatter of the next).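

In this assay the thiophen-2-yl exchange gives a number 3.9 percentage points lower from compound 2 to compound 3 (within the scatter) and also a number 5.3 percentage points lower from compound 1 to compound 3 (within the scatter) and so shows that replacing the whole six-membered aromatic ring on this carbon, not only moving its fluorine, produces no step beyond the scatter. All three compounds remain at low inhibition at the single concentration tested. Nothing available bears on a reason for this result.

From the compounds shown here alone, whether an amine or a carboxylic acid on this aromatic carbon would give a step beyond the scatter remains open. Also open, going by these compounds, is how these compounds would rank at other concentrations.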